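This account rests on a few compounds, and the source may have more. Where it says the series, first, only, none or still open, it means among the compounds named here.

In an ADME assay on Raji cells (Homo sapiens) for cytotoxicity, read by CellTiter-Glo, with a stated time of 72 h (a lower number here means that less compound is needed, a higher number that more compound is needed for the effect), compound 1 (`CC1=C2CC(C)(C)/C=C/C(=O)/C(C)=C\C3=C[C@H](C)C[C@]3(O2)[C@]1(C)O`) gives 26000 nM, compound 2 (`CC1=C2CC(C)(C)[C@@H]3C=C(OC3)/C(C)=C\C3=C[C@H](C)C[C@]3(O2)C1=O`) gives 26000 nM and compound 3 (`COc1ccc(/C2=C\C(=O)/C(C)=C\C3=C[C@H](C)C[C@@]34OC(=C(C)C4=O)CC2(C)C)cc1`) gives 26000 nM. Compound 3 therefore stands level with the other two, within the scatter. The change to compound 4 (`CC1=C2CC(C)(C)/C(c3ccccc3)=C/C(=O)/C(C)=C\C3=C[C@H](C)C[C@]3(O2)C1=O`) is hydrogen in place of methoxy on an aromatic carbon, so that 4-methoxyphenyl becomes phenyl. Among the compounds with values here, no measured pair differs in one place only, so no direct precedent exists. Compound 3 carries the 4-methoxyphenyl group and reads 26000 nM, while compound 2 lacks it and reads 26000 nM. On that basis, no change beyond the scatter is expected in either direction in this assay. The expected step is a 1.1-fold lower number from compound 3 to compound 4 (0.03 log units; within the scatter). For compound 4 the estimated value is 24000 nM, with an expected range of 10000 nM to 45000 nM.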

Compound 4, half-maximal effective concentration: 26000 nM
Estimate against measurement, compound 4: 1.1-fold (0.03 log units) below; the measured number falls inside the stated range.
By their numbers in this assay, from the lowest: compounds 1, 2, 3 and 4 (each within the scatter of the next).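

Within the data shown here, the first single-place pair of the series reads no change at the digits printed from compound 3 to compound 4 (within the scatter) in this assay. Among these compounds, on this aromatic carbon, para to a large group, 4-methoxyphenyl and phenyl are therefore interchangeable within the scatter, a direct reading that the earlier compounds, none differing in one place, could not give. Nothing available here accounts for this result. Going by these compounds, whether an amine or a carboxylic acid on that aromatic carbon would also read level with compound 4 stays open. So does the contribution of the phenyl group itself to the number.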